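Shortening the aryl chain by one carbon in compound 4

The compounds below may be only part of what the source reports. "The series", "measured", "known", "first", "only" and "open" are said of these compounds alone.

The study compares three uracil-based compounds that share a core and differ only in the group held on the triple-bonded carbon. Compound 1 `CCCCCCCCC#Cc1cn(C/C=C\CN2C(=O)c3ccccc3C2=O)c(=O)[nH]c1=O` carries an octyl chain there and, in a functional assay on HepG2 cells (Homo sapiens) for antiproliferative activity, read by MTT assay, with a stated time of 3 days (a lower number here means a stronger inhibitor, a higher number a weaker inhibitor), compound 1 gives 39000 nM. Compound 2 `O=C1c2ccccc2C(=O)N1C/C=C\Cn1cc(C#Cc2ccc(Br)cc2)c(=O)[nH]c1=O` carries a 4-bromophenyl group and gives 89000 nM. Compound 3 `CCCCCc1ccc(C#Cc2cn(C/C=C\CN3C(=O)c4ccccc4C3=O)c(=O)[nH]c2=O)cc1` carries a 4-pentylphenyl group and gives 18000 nM, the lowest of the three numbers: the step of a 2.2-fold lower number from compound 1 to compound 3 (0.34 log units; beyond the scatter) and the step of a 4.9-fold lower number from compound 2 to compound 3 (0.69 log units; beyond the scatter) both run toward compound 3.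

Compound 4 `CCCCc1ccc(C#Cc2cn(C/C=C\CN3C(=O)c4ccccc4C3=O)c(=O)[nH]c2=O)cc1` is the next step from compound 3. The change is hydrogen in place of methyl on a saturated chain carbon, four bonds along the chain from an aromatic carbon, which read one bond further out is pentyl to butyl.

Among the measured compounds shown here, none of the measured steps touches the length of this chain by a single carbon; the two steps that lead into compound 3 swap whole groups, and the step of a 2.3-fold higher number from compound 1 to compound 2 (0.36 log units; beyond the scatter) exchanges a chain for a halogenated ring. They show that the group on the triple-bonded carbon matters, but offer no reading for trimming a methyl from the pentyl. The expected step is therefore a 1.2-fold higher number from compound 3 to compound 4 (0.09 log units; within the scatter), within the scatter. For compound 4 the expected value is 22000 nM, with a range from 10000 nM to 45000 nM.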

Compound 4, half-maximal inhibitory concentration: 40000 nM
Beside the measured number, compound 4's estimate is 1.8-fold (0.26 log units) below it; the range from low to high includes it.
By their numbers in this assay, from the lowest: compound 3; then compounds 1 and 4 (each within the scatter of the next); then compound 2.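

In this assay, among the compounds shown here, the end of this chain proves sensitive to a single carbon: hydrogen in place of methyl, four bonds along the chain from an aromatic carbon, gives (a 2.2-fold higher number from compound 3 to compound 4 (0.35 log units; beyond the scatter)), a reading the whole-group swaps among the earlier compounds could not give. Butyl still stands apart from bromo on the aromatic carbon (a 2.2-fold lower number from compound 2 to compound 4 (0.35 log units; beyond the scatter)), but that step is shorter than the one pentyl gives in the same place (a 4.9-fold lower number from compound 2 to compound 3 (0.69 log units; beyond the scatter)). The 4-butylphenyl and octyl groups on the triple-bonded carbon cannot be told apart (a 1.0-fold higher number from compound 1 to compound 4 (0.01 log units; within the scatter)), so the separation seen with 4-pentylphenyl (a 2.2-fold lower number from compound 1 to compound 3 (0.34 log units; beyond the scatter)) does not persist once this one carbon is removed.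

Nothing at hand accounts for why this single carbon registers in the assay.

With only butyl and pentyl to compare, the compounds shown leave open whether a longer chain such as hexyl, a shorter one such as propyl, or a hydroxyl group at the chain end would extend this step or reverse it.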